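A Methoxy Group Added to a Permeability-Limited Core

A few compounds are considered here, and "the series" means these few. Any claim that something is new, unique, unknown or untested is made for them only; others in the source may bear on it.

Compound 1, `CNC(=O)c1cc(Oc2ccc3nc(Nc4ccccc4)ncc3c2)ccn1`, was tested in an ADME assay on Caco-2 cells (Homo sapiens) for permeability, in the apical to basolateral direction; on this read-out higher numbers stand for higher permeability and lower numbers for lower permeability. In this assay compound 1 gives < 1 10^-6 cm/s, which is a limit of the assay rather than a measured number. Compound 2, `CNC(=O)c1cc(Oc2ccc3nc(Nc4cccc(C(C)(C)C)c4)ncc3c2)ccn1`, differs from it by a tert-butyl in place of hydrogen on an aromatic carbon. In this assay compound 2 gives < 1 10^-6 cm/s, again a limit. The step that the two limits leave unreadable from compound 1 to compound 2 therefore cannot be sized, since (the limit of < 1 10^-6 cm/s in this assay, at which 2 of the 2 values shown sit). Compound 3, `CNC(=O)c1cc(Oc2ccc3nc(Nc4ccc(OC)cc4)ncc3c2)ccn1`, is not yet measured. Its difference from compound 1 is methoxy in place of hydrogen on an aromatic carbon. Going by the values given here, the only measured step, the one between compound 1 and compound 2, bears on it as another substitution on an aromatic carbon of the same ring, but its size is not readable, so no direction beyond the scatter can be drawn from it for the methoxy change. Both measured compounds sit at the same limit, and compound 3 is expected to remain close to it. For compound 3 the estimated value is 0.6 10^-6 cm/s, in a range from 0.2 10^-6 cm/s to 1.5 10^-6 cm/s, which means an expected step that the limit leaves unreadable from compound 1 to compound 3.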

Compound 3, apparent permeability: < 1 10^-6 cm/s
Compound 3: no number, only a limit; the forecaster's own chance of this, stated with the estimate: 75%; the middle value lies beyond the limit too.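

Compound 3 also returns a limit of the assay rather than a number, so its steps from compound 1 and from compound 2 cannot be read: the limit of < 1 10^-6 cm/s in this assay, at which 3 of the 3 values shown sit.

On these data alone, what stays open is how the true values of compound 1, compound 2 and compound 3 compare with one another in this assay.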